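The source may report more compounds than this note shows. Statements on the series, on what has been measured and on what is new or still open speak of the compounds shown alone.

Compound 1 `CSc1ccc(Cc2nn(-c3ccccc3)c(=O)c3ccccc23)cc1` carries a phenyl on an aromatic nitrogen of the shared core. In a functional assay on aorta with Alpha-1D adrenergic receptor (Rattus norvegicus) as the target (on this read-out higher numbers stand for an effect only at larger amounts of compound and lower numbers for an effect already at smaller amounts), compound 1 gives > 100000 nM, which is a limit of the assay and not a number. Compound 2 `CSc1ccc(Cc2nn(-c3ccc([N+](=O)[O-])cc3)c(=O)c3ccccc23)cc1` bears a nitro in place of hydrogen on an aromatic carbon. In this assay compound 2 gives > 100000 nM, again only a limit. Compound 3 `C=CCn1nc(Cc2ccc(SC)cc2)c2ccccc2c1=O` carries an allyl on the aromatic nitrogen instead. In this assay compound 3 gives > 100000 nM, also a limit. Compound 3 thus stands where the other two values stand, as the limit of > 100000 nM in this assay, at which 3 of the 3 values shown sit, records. The step that the two limits leave unreadable from compound 1 to compound 3 and the step that the two limits leave unreadable from compound 2 to compound 3 both change the group on this nitrogen, yet neither can be read in size. Compound 4 `CSc1ccc(Cc2nn(-c3ccc(Br)cc3)c(=O)c3ccccc23)cc1` is not yet measured; it differs from compound 3 by 4-bromophenyl in place of allyl on an aromatic nitrogen. Given (the limit of > 100000 nM in this assay, at which 3 of the 3 values shown sit), a phenyl with or without a substituent has shown no readable effect, so the expected step is a step that the limit leaves unreadable from compound 3 to compound 4, none beyond the scatter. Compound 4 is therefore expected to give 150000 nM, within a range of 30000 nM to 1000000 nM, most likely again reported only as a limit.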

Compound 4, half-maximal effective concentration: > 100000 nM
Compound 4 was reported as a limit; the forecaster's own chance of this, stated with the estimate: 85%; the middle value does not contradict the limit.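

Among the compounds shown here, compound 4 joins compound 1, compound 2 and compound 3 at a limit of the assay and not a number, so no step among them can be read in size: the limit of > 100000 nM in this assay, at which 4 of the 4 values shown sit.

The compounds shown leave open whether, in this assay, any group on this nitrogen or any other change to the shared core gives a readable value.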